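Replacing the amino on the sulfonyl sulfur of compound 2

The source may hold more compounds than are shown below. What is called first, only, known or untested is meant among the compounds shown, and "the series" means these compounds.

In a functional assay on the whole organism (strain Sprague-Dawley) for inhibition, with Rattus norvegicus as the target, with a stated time of 10 min (on this read-out higher numbers stand for an effect only at larger amounts of compound and lower numbers for an effect already at smaller amounts), compound 1 `CCOC(=O)c1cnc(-c2cc([N+](=O)[O-])ccc2OCC)[nH]c1=O` gives 5 mg/kg and compound 2 `CCOC(=O)c1cnc(-c2cc(S(N)(=O)=O)ccc2OCC)[nH]c1=O` gives 50 mg/kg, the higher of the two numbers. Compound 3 `CCOC(=O)c1cnc(-c2cc(S(=O)(=O)N(C)C(C)C)ccc2OCC)[nH]c1=O` keeps the core of compound 2 and carries isopropyl(methyl)amino in place of amino on a sulfonyl sulfur. For the measured compounds named here, only one measured step bears on this, sulfamoyl in place of nitro on an aromatic carbon, and it gives a 10-fold higher number from compound 1 to compound 2 (1.00 log units; beyond the scatter). Going by the values given here, that step exchanges a different group, and no measured pair covers substitution on the sulfonyl sulfur. It serves only as a guide to size, so a modest change is expected, tentatively towards a lower number. The expected step is a 2.5-fold lower number from compound 2 to compound 3 (0.40 log units; beyond the scatter). For compound 3 the estimated value is 20 mg/kg, with an expected range of 4 mg/kg to 100 mg/kg.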

Compound 3, dose for 50% inhibition: > 10 mg/kg
Compound 3 gave a limit, no number; the forecaster's own chance of this, stated with the estimate: 15%; the middle value does not contradict the limit.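

In this assay, compound 3 is the only compound shown with a substituent on the sulfonyl sulfur, and it gives a limit, not a number: the limit of > 10 mg/kg in this assay, at which 1 of the 3 values shown sits. The step from compound 2 to compound 3 cannot be read, so this change is not shown to move the value in either direction, and the loss of the amino group's hydrogen-bond donor cannot be tied to any effect. For the compounds shown here, the only readable comparison is an at least 2.0-fold higher number from compound 1 to compound 3 (0.30 log units; that floor lies within the scatter), so that floor does not separate isopropyl(methyl)sulfamoyl from nitro on the aromatic carbon.

The compounds shown leave open where compound 3 lies relative to compound 2 on a numerical scale. They also leave open whether a smaller group on the sulfonyl sulfur, such as methylamino or dimethylamino, would give a readable value.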